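A few compounds are considered here, and "the series" means these few. Any claim that something is new, unique, unknown or untested is made for them only; others in the source may bear on it.

In a functional assay on K562 cells (Homo sapiens), read by MTT assay, with a stated time of 72 h (a lower number here means a stronger inhibitor, a higher number a weaker inhibitor), compound 1 `COc1ncnc2c1c(-c1ccccc1)cn2[C@@H]1O[C@H](CO)[C@@H](O)[C@H]1O` gives > 20000 nM, which is a limit of the assay. Going by the values given here, compound 2 `COc1ncnc2c1c(-c1cc3ccccc3o1)cn2[C@@H]1O[C@H](CO)[C@@H](O)[C@H]1O` gives 20900 nM in this assay, the only actual number so far. Compound 3 `C#Cc1cn([C@@H]2O[C@H](CO)[C@@H](O)[C@H]2O)c2ncnc(OC)c12` carries ethynyl in place of 1-benzofuran-2-yl on an aromatic carbon. Among the compounds with values here, the one measured step, a step that the limit leaves unreadable from compound 1 to compound 2, cannot be sized because of the limit of > 20000 nM in this assay, at which 1 of the 2 values shown sits, so it sets no scale for this change. A moderate gain in this assay is expected only tentatively, with wide uncertainty. The expected change is a 2.6-fold lower number from compound 2 to compound 3 (0.42 log units; beyond the scatter). For compound 3 the estimated value is 8000 nM, with an expected range of 800 nM to 30000 nM.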

Compound 3, half-maximal inhibitory concentration: 300 nM
Estimate against measurement, compound 3: 27-fold (1.43 log units) above; measured number below the stated range.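

At this aromatic carbon, the number in this assay moves strongly once ethynyl, with no ring, takes the place of an aromatic ring group: a 70-fold lower number from compound 2 to compound 3 (1.84 log units; beyond the scatter). Against phenyl the change is also large: an at least 66-fold lower number from compound 1 to compound 3 (1.82 log units; beyond the scatter). That step is only a lower bound because the value of compound 1 is a limit: the limit of > 20000 nM in this assay, at which 1 of the 3 values shown sits.

With ethynyl the only group without a ring here, the compounds shown leave open whether the triple bond itself matters or only the absence of a ring. A nitrile, a vinyl group or an ethyl chain at this carbon would separate the two.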